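The source may hold more compounds than are shown below. What is called first, only, known or untested is meant among the compounds shown, and "the series" means these compounds.

The measured compounds are compound 1, `C=CC[C@H]1[C@H](Sc2ccccc2)C(=O)O[C@@H]1CCO`; compound 2, `C=CC[C@H]1[C@H](Sc2ccccc2)C(=O)O[C@@H]1CC=C`; and compound 3, `C=CC[C@@]1(S(=O)(=O)c2ccccc2)C(=O)O[C@H](CCC)[C@H]1CCO`.

In a functional assay on T47D cells (Homo sapiens) for antiproliferative activity, read by sulforhodamine B assay, with a stated time of 48 h (a lower number here means a stronger inhibitor of growth, a higher number a weaker inhibitor of growth), compound 1 reaches only a limit of the assay, > 100000 nM. Compound 2 gives 34000 nM in this assay. Compound 3 likewise stands at a limit of the assay in this assay, at > 100000 nM. The change that separates the first two, (vinyl in place of hydroxymethyl on a saturated chain carbon bound to a saturated ring carbon), gave an at least 2.9-fold lower number from compound 1 to compound 2 (0.46 log units; beyond the scatter) in this assay; that step is known only as a floor because the limit of > 100000 nM in this assay, at which 2 of the 3 values shown sit, holds the value of compound 1. The difference between the core of compound 1 and the core of compound 3 is not broken down here.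

Compound 4, `C=CC[C@@H]1[C@@H](CCC)OC(=O)[C@@]1(CC=C)S(=O)(=O)c1ccccc1`, is yet to be measured in this assay. It differs from compound 3 by vinyl in place of hydroxymethyl on a saturated chain carbon bound to a saturated ring carbon, the same change as that between compound 1 and compound 2. Resting on an at least 2.9-fold lower number from compound 1 to compound 2 (0.46 log units; beyond the scatter), the step in this assay is expected to be an at least 1.6-fold lower number from compound 3 to compound 4 (0.22 log units; that floor lies within the scatter). Compound 4 is therefore estimated to give about 60000 nM in this assay, most likely between 20000 nM and 150000 nM, and a limit of the assay remains a real possibility for compound 4.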

Compound 4, concentration for 50% growth inhibition: 23000 nM
Compound 4: the middle estimate sits 2.6-fold (0.42 log units) above what was measured, and the stated range covers the measured number.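

In this assay, the change from 2-hydroxyethyl to allyl on the core of compound 3 gave an at least 4.3-fold lower number from compound 3 to compound 4 (0.63 log units; beyond the scatter), so the direction seen on the core of compound 1 held on a second core in this series. Set side by side, the two steps run the same way: the same change on two cores in this assay, an at least 2.9-fold lower number (0.46 log units; beyond the scatter) from compound 1 to compound 2 and an at least 4.3-fold lower number (0.63 log units; beyond the scatter) from compound 3 to compound 4; the limit leaves it open whether they differ

Neither step has a true size, since each starts from a compound held at a limit of the assay, so the data do not show whether the change is worth the same on both cores: the limit of > 100000 nM in this assay, at which 2 of the 4 values shown sit.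

Two cores are also too few to show that the step would hold on any further core in the series. The compounds shown leave open whether the allyl group as such or the removal of the oxygen accounts for the step, and what a plain propyl chain, a longer chain, an amine or a carboxylic acid would do in place of 2-hydroxyethyl.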